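Moving the Hydroxy Group: 2-Hydroxyphenyl to 4-Hydroxyphenyl

The compounds below may be only part of what the source reports. "The series", "measured", "known", "first", "only" and "open" are said of these compounds alone.

Among the measured compounds shown here, in a functional assay on ACHN cells (Homo sapiens) for inhibition, read by sulforhodamine B assay, with a stated time of 48 h (on this read-out lower numbers stand for stronger inhibition of growth and higher numbers for weaker inhibition of growth), compound 1 `O=C(Cc1csc2nc(-c3ccc(Br)cc3)cn12)N/N=C/c1ccccc1` gives 25700 nM, while compound 2 `O=C(Cc1csc2nc(-c3ccc(Br)cc3)cn12)N/N=C/c1ccccc1O` gives 6310 nM, the lower of the two numbers so far. For the measured compounds named here, the only measured step is a 4.1-fold lower number from compound 1 to compound 2 (0.61 log units; beyond the scatter), which comes from hydroxy in place of hydrogen on an aromatic carbon. Compound 3 `O=C(Cc1csc2nc(-c3ccc(Br)cc3)cn12)N/N=C/c1ccc(O)cc1` has the same atoms as compound 2, joined differently: 4-hydroxyphenyl in place of 2-hydroxyphenyl on a carbon with a double bond to nitrogen. In words, 4-hydroxyphenyl stands in place of 2-hydroxyphenyl on a carbon with a double bond to nitrogen. Going by the values given here, no measured step tests such a move directly. Compound 3 keeps the hydroxy group, so the whole of a 4.1-fold lower number from compound 1 to compound 2 (0.61 log units; beyond the scatter) is not expected to be lost, though part of it might be. The expected change is a 1.6-fold higher number from compound 2 to compound 3 (0.20 log units; within the scatter), with no large shift in this assay anticipated. For compound 3 the estimated value is 10000 nM, with an expected range from 3500 nM to 25000 nM.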

Compound 3, concentration for total growth inhibition: 51300 nM
Compound 3: the middle estimate sits 5.1-fold (0.71 log units) below what was measured; the whole stated range lies below it.
By their numbers in this assay, from the lowest: compound 2; then compounds 1 and 3 (each within the scatter of the next).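

In this assay, the presence of a hydroxy group is not enough on its own: with the same atoms joined differently, 4-hydroxyphenyl in place of 2-hydroxyphenyl on a carbon with a double bond to nitrogen gives an 8.1-fold higher number from compound 2 to compound 3 (0.91 log units; beyond the scatter). Measured against the ring with no hydroxy group, 4-hydroxyphenyl gives a 2.0-fold higher number from compound 1 to compound 3 (0.30 log units; within the scatter), so the gain seen with 2-hydroxyphenyl does not carry over to 4-hydroxyphenyl. Nothing measured here accounts for the difference between these two groups.

As far as these compounds go, it remains open whether a methoxy group or an amine in place of the hydroxy group of 2-hydroxyphenyl would give a number like that of compound 2. Also open, from the compounds shown here alone, is whether the gap between compound 2 and compound 3 would persist with chloro in place of the bromo group on the shared core.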